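This account rests on a few compounds, and the source may have more. Where it says the series, first, only, none or still open, it means among the compounds named here.

Measured compounds:
Compound 1 `COc1ccc(CNc2nc([Se]C)nc3ccccc23)cc1`, > 100000 nM in a functional assay on CCRF-CEM cells (Homo sapiens) for cytotoxicity, read by MTT assay, with a stated time of 72 h; on this read-out higher numbers stand for lower toxicity in this test and lower numbers for higher toxicity in this test
Compound 2 `C[Se]c1nc([Se]C)c2cccnc2n1` gives "not determined" (no result reported).

For compound 1 the value in this assay is a limit of the assay, not a number (the limit of > 100000 nM in this assay, at which 1 of the 2 values shown sits). Compound 2 has no number in this assay at all, so on the values shown it stands nowhere. Compound 3 `C[Se]c1nc(N)c2cccnc2n1` differs from compound 2 in one nitrogen atom in place of a group of 2 heavy atoms (1 carbon, 1 selenium; no ring), on an aromatic carbon. Among the compounds with values here, with no measured step available, no direction or size beyond the scatter can be expected. Compound 3 is estimated at 80000 nM, within 10000 nM to 300000 nM.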

Compound 3, concentration lethal to 50% of the cells: > 100000 nM
Compound 3: a limit, no number; the forecaster's own chance of this, stated with the estimate: 60%; middle value at least 1.2-fold (0.09 log units) away from the limit.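

No step can be read from compound 2, which has no number, to compound 3, whose value is a limit and not a number: the limit of > 100000 nM in this assay, at which 2 of the 3 values shown sit. The compounds shown leave open what the amino group changes in toxicity.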